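The compounds below may be only part of what the source reports. "The series", "measured", "known", "first", "only" and "open" are said of these compounds alone.

Compound 1, with structure `C[C@@H](NC(=O)Nc1ccccc1F)c1ccccc1`, is one of two measured compounds in an ADME assay on the whole organism with Oryza sativa as the target, tested at 1 uM (a higher number here means a weaker effect of the compound at the concentration tested, a lower number a stronger effect), where compound 1 gives 95%. That is the lower of the two numbers. For the measured compounds named here, the only neighbour is compound 2, with structure `C[C@@H](NC(=O)Nc1ccccc1Br)c1ccccc1`, which in this assay gives 100%; the step of a number 5 percentage points higher from compound 1 to compound 2 (within the scatter) stays within the scatter, so the two compounds cannot be told apart on this assay.

The next compound, compound 3 with structure `C[C@@H](NC(=O)Nc1cc(C(F)(F)F)ccc1F)c1ccccc1`, differs from compound 1 by trifluoromethyl in place of hydrogen on an aromatic carbon. Going by the values given here, no measured step involves a trifluoromethyl group entering, so the single step from compound 1 to compound 2 is the only guide, and it shows no movement beyond the scatter for a change on the same ring. On that thin basis, compound 3 is expected to sit close to compound 1, with the step of no change at the digits printed from compound 1 to compound 3 (within the scatter) estimated to stay within the scatter.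

The estimate for compound 3 in this assay is therefore 95%, in a range from 80% to 100%.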

Compound 3, a percentage reported as activity, at one concentration (the size of the read-out at that concentration, not a potency): 70%
For compound 3 the middle estimate is 25 percentage points above the measured one; measured number below the stated range.
By their numbers in this assay, from the lowest: compound 3; then compounds 1 and 2 (each within the scatter of the next).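

In this assay, trifluoromethyl in place of hydrogen, on the aromatic carbon meta to a large group and para to a fluoro group, gives a number 25 percentage points lower from compound 1 to compound 3 (beyond the scatter) and so marks this carbon as a place where a substitution can strengthen the effect at the concentration tested. For the compounds shown here, it is the first step here to pass beyond the scatter, whereas the earlier change on the same ring, bromo in place of fluoro, gave a number 5 percentage points higher from compound 1 to compound 2 (within the scatter) and could not be told apart from no change. Nothing available explains why the number falls at this position.

On these data alone, it remains open whether a methyl group, a methoxy group or an amine on this carbon would move the number as well. As far as these compounds go, it is also open whether trifluoromethyl would give a similar step on another carbon of the ring.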